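A few compounds are considered here, and "the series" means these few. Any claim that something is new, unique, unknown or untested is made for them only; others in the source may bear on it.

Measured so far:
- compound 1 `Cc1nn([C@H](C)c2ccc(Cl)cc2Cl)c2nc(N3CC[C@H](N4CCC4)[C@H](C)C3)cnc12`: 218 nM
- compound 2 `C[C@@H]1CC(c2cnc3c(C#N)nn([C@H](C)c4ccc(Cl)cc4Cl)c3n2)=CC[C@@H]1N1CCC[C@H]1C(C)(C)O`: 1200 nM
- compound 3 `Cc1nn([C@H](C)c2ccc(Cl)cc2Cl)c2nc(C3=CC[C@H](N4CCC[C@H]4CO)[C@H](C)C3)cnc12`: 179 nM

In an assay on CCRF-CEM cells for antagonist activity at C-C chemokine receptor type 4 (Homo sapiens), read by CellTiter-Glo, with stated times of 30 min and 60 min, in the presence of a further agent that is not named here (on this read-out lower numbers stand for stronger inhibition and higher numbers for weaker inhibition), compound 1 gives 218 nM. Among the three numbers this is the second highest, but the nearest one, that of compound 3, lies within the usual scatter, so the two cannot be told apart; only compound 2 stands clearly apart, with a weaker number.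

Compound 4 `Cc1nn([C@H](C)c2ccc(Cl)cc2Cl)c2nc(N3CC[C@H](N4CCC[C@H]4CCC(N)=O)[C@H](C)C3)cnc12` is not yet measured. It differs from compound 1 in one place: 2-(2-carbamoylethyl)pyrrolidin-1-yl in place of azetidin-1-yl on a saturated ring carbon. Compound 3 already carries a substituted pyrrolidine and gives 179 nM, close to compound 1, so a pyrrolidine with a side chain is not, by itself, a cause for concern. The added carbamoylethyl chain is longer than anything seen here, so some uncertainty remains.

Compound 4 is expected to stay within the scatter of compound 1, a step of a 1.2-fold higher number from compound 1 to compound 4 (0.08 log units; within the scatter). The estimate for compound 4 is 260 nM, with a range from 80 nM to 900 nM.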

Compound 4, half-maximal inhibitory concentration: 355 nM
Compound 4: the middle estimate sits 1.4-fold (0.14 log units) below what was measured; low and high end bracket the measured number.
By their numbers in this assay, from the lowest: compounds 3, 1 and 4 (each within the scatter of the next); then compound 2.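

Replacing azetidin-1-yl with 2-(2-carbamoylethyl)pyrrolidin-1-yl on this saturated ring carbon gives a 1.6-fold higher number from compound 1 to compound 4 (0.21 log units; within the scatter) in this assay and so no change that can be told from the scatter. This position therefore tolerates a much larger group, one that brings a side chain ending in an amide. Nothing measured here explains this result.

From the compounds shown here alone, it remains open whether the pyrrolidine ring and the side chain each matter on their own. Going by these compounds, it is also open how this position would respond to a carboxylic acid or an amine at the end of the chain, or to a longer chain.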